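Working notes: from compound 3 to compound 4

The compounds below may be only part of what the source reports. "The series", "measured", "known", "first", "only" and "open" are said of these compounds alone.

Measured so far:
Compound 1 `Nc1ccc(-c2cc(=O)c3c(N)c(F)cc(F)c3o2)cc1F` in a functional assay on HeLa cells (Homo sapiens) for cytotoxicity, read by neutral red uptake, with a stated time of 3 days (a lower number here means a stronger inhibitor, a higher number a weaker inhibitor), sits at the limit > 100000 nM.
Compound 2 `[N-]=[N+]=Nc1c(F)c(N)c2c(=O)cc(-c3ccc(N)c(F)c3)oc2c1F` gives 1200 nM.
Compound 3 `CN(C)CC(=O)OCc1c(F)c(N)c2c(=O)cc(-c3ccc(N)c(F)c3)oc2c1F` gives 9200 nM.

Compound 3 holds the highest of the two numbers; its nearest neighbour is compound 2, with a 7.7-fold higher number from compound 2 to compound 3 (0.88 log units; beyond the scatter). Compound 1 contributes only a limit, (the limit of > 100000 nM in this assay, at which 1 of the 3 values shown sits).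

Compound 4 `CN(C)Cc1c(F)c(N)c2c(=O)cc(-c3ccc(N)c(F)c3)oc2c1F` differs from compound 3 by dimethylamino in place of (((dimethylamino)methyl)carbonyl)oxy on a saturated chain carbon bound to an aromatic carbon. Among the compounds with values here, two measured steps touch the same aromatic carbon: an at least 10-fold lower number from compound 1 to compound 3 (1.03 log units; beyond the scatter) and an at least 83-fold lower number from compound 1 to compound 2 (1.92 log units; beyond the scatter), both large, showing that what sits there moves the number strongly. Within the data shown here, no measured pair, however, shortens the substituent while keeping the amine, so the direction is open. A modest step within the broad band set by compounds 2 and 3 is expected: compound 4 is estimated at 5000 nM, from 1000 nM to 40000 nM, meaning a 1.8-fold lower number from compound 3 to compound 4 (0.26 log units; within the scatter).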

Compound 4, half-maximal inhibitory concentration: 8900 nM
Compound 4: the middle estimate sits 1.8-fold (0.25 log units) below what was measured; the range from low to high includes it.
By their numbers in this assay, from the lowest: compound 2; then compounds 4 and 3 (each within the scatter of the next). At a limit, above all of these: compound 1.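

In this assay dimethylamino in place of (((dimethylamino)methyl)carbonyl)oxy on a saturated chain carbon bound to an aromatic carbon leaves compound 3 and compound 4 within the scatter of each other (a 1.0-fold lower number from compound 3 to compound 4 (0.01 log units; within the scatter)), so the carbonyloxy portion is not needed for this level of activity. Azido on the aromatic carbon still gives the lowest number (a 7.4-fold higher number from compound 2 to compound 4 (0.87 log units; beyond the scatter)). Compound 1 stands at a limit of the assay, so the step to (dimethylamino)methyl is only a bound (an at least 11-fold lower number from compound 1 to compound 4 (1.05 log units; beyond the scatter)).

Open, going by these compounds, is how a primary amine, a carboxylic acid or a longer chain in place of dimethylamino would read in this assay on this saturated chain carbon.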